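The compounds below may be only part of what the source reports. "The series", "measured", "known", "first", "only" and "open" are said of these compounds alone.

Measured in an assay on MCF7 cells for inhibition of Serine-protein kinase ATM (Homo sapiens), read by immunofluorescence, with a stated time of 1 h; on this read-out lower numbers stand for stronger inhibition and higher numbers for weaker inhibition:
Compound 1 `Nc1nc(-c2ccccc2)nn1-c1ncnc2cc(Cl)ccc12` gives > 40000 nM, a limit of the assay.
Compound 2 `Nc1nc(-c2ccccn2)nn1-c1ncnc2cc(N3CCNCC3)c([N+](=O)[O-])cc12` gives > 40000 nM, a limit of the assay.
Compound 3 `COc1cc2ncnc(-n3nc(-c4ccncc4)nc3N)c2cc1OC` gives 5000 nM.

Among the measured compounds shown here, compound 3 thus stands as the only actual number among the three results, the other two resting at the assay ceiling (the limit of > 40000 nM in this assay, at which 2 of the 3 values shown sit). The unmeasured compound 4 `COc1cc2ncnc(-n3nc(C4CCCCC4)nc3N)c2cc1OC` differs from compound 3 by cyclohexyl in place of pyridin-4-yl on an aromatic carbon. For the measured compounds named here, no measured pair shows this exchange, so the step is uncharted. Weaker inhibition is expected, by a margin beyond the usual scatter. Compound 4 is expected to give 15000 nM, within 4000 nM to 40000 nM. For compound 4 the expected step is a 3.0-fold higher number from compound 3 to compound 4 (0.48 log units; beyond the scatter).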

Compound 4, half-maximal inhibitory concentration: > 40000 nM
Compound 4 ended at the assay's limit; the forecaster's own chance of this, stated with the estimate: 40%; at least 2.6-fold (0.42 log units) between middle value and limit.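

Among the compounds shown here, putting cyclohexyl in place of pyridin-4-yl on this aromatic carbon of the five-membered ring gives an at least 8.0-fold higher number from compound 3 to compound 4 (0.90 log units; beyond the scatter), the first step that can be read at this position. On this core, the carbon-only non-aromatic ring of the same heavy-atom size does not keep a measurable number, and the step is only a lower bound. Compound 4 joins the compounds at a limit of the assay: the limit of > 40000 nM in this assay, at which 3 of the 4 values shown sit.

The pair cannot separate the loss of the ring nitrogen from the loss of the aromatic ring. Piperidin-4-yl or pyridin-3-yl at this position on the same core would bear on that question.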